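This account rests on a few compounds, and the source may have more. Where it says the series, first, only, none or still open, it means among the compounds named here.

Measured so far:
- compound 1 `O=c1oc2ccccc2n1CCN1CCN(c2ccccc2)CC1`: in a functional assay on the whole organism with Mus musculus as the target (on this read-out higher numbers stand for an effect only at larger amounts of compound and lower numbers for an effect already at smaller amounts), compound 1 gives > 50 mg/kg, which is a limit of the assay and not a number.
- compound 2 `COc1ccccc1N1CCN(CCn2c(=O)oc3cccnc32)CC1`: in this assay compound 2 gives > 50 mg/kg, again a limit of the assay rather than a number.

Among the compounds with values here, compound 2 therefore stands at the limit of > 50 mg/kg in this assay, at which 2 of the 2 values shown sit, the same place where the only other value shown sits. Between compound 1 and compound 2 nothing separates the two results, and no step between measured compounds has been worked out, so there is no measured change in this assay to lean on.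

Compound 3 `O=c1oc2cccnc2n1CCN1CCN(c2ccc(Cl)cc2)CC1` has not yet been measured. It differs from compound 2 in one place: 4-chlorophenyl in place of 2-methoxyphenyl on an amine nitrogen in a ring.

With both known values at the limit, there is no measured direction to carry over. The step that the limit leaves unreadable from compound 2 to compound 3 is expected to be small, with no clear move in either direction beyond the usual scatter. For compound 3 the estimate is 60 mg/kg, with a range from 20 mg/kg to 200 mg/kg, and a considerable chance that the assay once more reports only a limit.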

Compound 3, dose for half-maximal effect: > 50 mg/kg
Compound 3 ended at the assay's limit; the forecaster's own chance of this, stated with the estimate: 70%; the middle value does not contradict the limit.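

Compound 2 and compound 3 both end at a limit of this assay, so the step of 4-chlorophenyl in place of 2-methoxyphenyl cannot be read: the limit of > 50 mg/kg in this assay, at which 3 of the 3 values shown sit.

The compounds shown leave open whether this swap on the amine nitrogen makes any difference in this assay, and what dose any of them would need for a half-maximal effect.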